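The compounds below may be only part of what the source reports. "The series", "measured", "known", "first", "only" and "open" are said of these compounds alone.

Measured so far in a functional assay on DU-145 cells (Homo sapiens) for inhibition, read by trypan blue exclusion, with a stated time of 96 h; a higher number here means a weaker inhibitor of growth, a lower number a stronger inhibitor of growth:
Compound 1, `CC(=O)c1ccc(/C=C(/Sc2ccc(C)cc2)C(=O)c2ccc(Br)cc2)cc1`, gives 50000 nM.
Compound 2, `Cc1ccc(S/C(=C/c2c(O)cc(O)cc2O)C(=O)c2ccc(Cl)cc2)cc1`, gives only an assay limit, > 100000 nM.
Compound 3, `COc1ccc(/C=C(/Sc2ccc(C)cc2)C(=O)c2ccc(Cl)cc2)cc1`, gives 1000 nM.

Compound 3 stands at the lowest of the two numbers in this assay; compound 1 sits well above it, beyond the scatter, and compound 2 shows only the limit described in the limit of > 100000 nM in this assay, at which 1 of the 3 values shown sits. Going by the values given here, the one step measured is an at least 100-fold lower number from compound 2 to compound 3 (2.00 log units; beyond the scatter), and it concerns the aryl group on the double-bonded chain carbon, not the halogen on the carbonyl-bearing ring.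

Compound 4 is `COc1ccc(/C=C(/Sc2ccc(C)cc2)C(=O)c2ccc(Br)cc2)cc1`. The change from compound 3 is bromo in place of chloro on an aromatic carbon. Among the compounds with values here, no measured pair differs only in this halogen: compound 1 and compound 3 differ both in the halogen and in the aryl group on the chain carbon, so their values give no separate reading of the halogen swap. Within the data shown here, with no step bearing on it, the expectation is no step beyond the scatter, no change at the digits printed from compound 3 to compound 4 (within the scatter). Compound 4 is therefore estimated at 1000 nM, with a range from 400 nM to 3000 nM.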

Compound 4, concentration for 50% growth inhibition: 50000 nM
Beside the measured number, compound 4's estimate is 50-fold (1.70 log units) below it, and the stated range ends below it.
By their numbers in this assay, from the lowest: compound 3; then compounds 1 and 4 (each within the scatter of the next). At a limit, above all of these: compound 2.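

In this assay, the halogen at this position carries much of the reading: with the methoxy group held fixed, bromo in place of chloro on the aromatic carbon, para to a large group, gives a 50-fold higher number from compound 3 to compound 4 (1.70 log units; beyond the scatter) as the first direct measure of this swap. This shows that a single-atom exchange at this site can move the number as far as the much larger aryl change in the earlier step, so the 4-chlorophenyl to 4-bromophenyl change cannot be treated as neutral in this series. With bromo held fixed, methoxy in place of acetyl on an aromatic carbon gives no change at the digits printed from compound 1 to compound 4 (within the scatter), so that aryl change shows no effect in the bromo pair, and the series offers no measured explanation for either result.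

The compounds shown leave open whether the large halogen step also appears with acetyl in place of methoxy, since the halogen swap can be read only in the methoxy pair. They also leave open how fluoro, iodo, nitrile or an amine on the same aromatic carbon would read against chloro and bromo.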